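The compounds below may be only part of what the source reports. "The series", "measured", "known", "first", "only" and "open" are said of these compounds alone.

Going by the values given here, in a functional assay on NCI-H460 cells (Homo sapiens) for inhibition, read by MTT assay, with a stated time of 48 h (on this read-out lower numbers stand for stronger inhibition of growth and higher numbers for weaker inhibition of growth), compound 2 `COc1ccccc1-c1cc(-c2ccccc2-c2ccccc2)n[nH]1` gives 9100 nM, the lower of the two numbers measured so far, while compound 1 `Oc1ccc(-c2cc(-c3ccc(C(F)(F)F)cc3)n[nH]2)cc1` gives 20100 nM, a gap beyond the usual scatter. Compound 3 `Nc1ccc(-c2cc(-c3ccccc3-c3ccccc3)n[nH]2)cc1` has not yet been measured. It differs from compound 2 in one place: 4-aminophenyl in place of 2-methoxyphenyl on an aromatic carbon. Among the compounds with values here, no measured step of this kind exists among the compounds at hand, so the change cannot be weighed against a precedent. The expected step is a 1.3-fold higher number from compound 2 to compound 3 (0.12 log units; within the scatter), a modest movement toward weaker inhibition that may not exceed the scatter. Compound 3 is estimated at 12000 nM, with a likely range from 4000 nM to 40000 nM.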

Compound 3, concentration for 50% growth inhibition: 8200 nM
Estimate against measurement, compound 3: 1.5-fold (0.17 log units) above; low and high end bracket the measured number.
By their numbers in this assay, from the lowest: compounds 3 and 2 (each within the scatter of the next); then compound 1.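

In this assay, 4-aminophenyl in place of 2-methoxyphenyl on this aromatic carbon gives a 1.1-fold lower number from compound 2 to compound 3 (0.05 log units; within the scatter). At this position of the shared core, the exchange therefore leaves the read-out within the scatter, even though the entering group carries a hydrogen-bond donor and the leaving group carries none. No measurement is available that bears on why this is so. The compounds shown leave open whether a carboxylic acid or a dimethylamino group on this phenyl ring would move the number beyond the scatter.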